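Ethoxy homologue of compound 2 in the reporter assay

The compounds below may be only part of what the source reports. "The series", "measured", "known", "first", "only" and "open" are said of these compounds alone.

Among the measured compounds shown here, compound 2 `COc1cc(C(=O)O)nc2ccc(-c3ccc(OCc4c(-c5c(Cl)cccc5Cl)noc4C(C)C)cc3)cc12` stands at the lower of the two numbers measured so far in a functional assay on CV-1 cells for agonist activity at Bile acid receptor (Homo sapiens), read by a luciferase reporter; a higher number here means that more compound is needed for the effect, a lower number that less compound is needed: compound 2 gives 17 nM. For the measured compounds named here, compound 1 `CC(C)c1onc(-c2c(Cl)cccc2Cl)c1COc1ccc(-c2ccc3nc(C(=O)O)cc(O)c3c2)cc1` gives 10000 nM in this assay, and the only measured step, a 590-fold lower number from compound 1 to compound 2 (2.77 log units; beyond the scatter), is a methyl in place of hydrogen on an oxygen on an aromatic ring. Compound 3 `CCOc1cc(C(=O)O)nc2ccc(-c3ccc(OCc4c(-c5c(Cl)cccc5Cl)noc4C(C)C)cc3)cc12` carries the change methyl in place of hydrogen on a saturated chain carbon bound to an oxygen on an aromatic ring relative to compound 2. Going by the values given here, no measured step touches this saturated chain carbon; the large step recorded between compound 1 and compound 2 concerns the oxygen itself, not the chain bound to it, and so gives no direct guide to the size of the present change. Growing methoxy to ethoxy is expected to leave the number close to where it is, with an expected step of a 1.5-fold higher number from compound 2 to compound 3 (0.17 log units; within the scatter), within the usual scatter. For compound 3 the estimate in this assay is 25 nM, with a range from 8 nM to 80 nM.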

Compound 3, half-maximal effective concentration: 14 nM
For compound 3 the middle estimate is 1.8-fold (0.25 log units) above the measured one; low and high end bracket the measured number.
By their numbers in this assay, from the lowest: compounds 3 and 2 (each within the scatter of the next); then compound 1.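

In this assay, among the compounds shown here, methoxy growing to ethoxy gives a 1.2-fold lower number from compound 2 to compound 3 (0.08 log units; within the scatter), so methyl in place of hydrogen on this saturated chain carbon bound to an oxygen on an aromatic ring, a place no earlier step touched, leaves compound 3 within the scatter of compound 2. Ethyl in place of hydrogen on the oxygen gives a 710-fold lower number from compound 1 to compound 3 (2.85 log units; beyond the scatter), which shows that the large step first seen with methyl is not confined to that one group. No data at hand bear on the reason for either step.

From the compounds shown here alone, how far the chain can grow remains open: a longer chain such as butyl, or a chain ending in an amine or a carboxylic acid, could still fall outside this scatter. Whether an acetyl group on the same oxygen would match methyl and ethyl is also unresolved.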